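A few compounds are considered here, and "the series" means these few. Any claim that something is new, unique, unknown or untested is made for them only; others in the source may bear on it.

Measured so far, working notes on the series:
- compound 1 `O=C1/C(=C/c2ccncc2)CN(S(=O)(=O)c2ccc(Cl)cc2)C/C1=C\c1ccccc1F`: 9600 nM
- compound 2 `O=C1/C(=C/c2ccncc2)CN(S(=O)(=O)c2ccc([N+](=O)[O-])cc2)C/C1=C\c1ccccc1C(F)(F)F`: > 20000 nM
- compound 3 `O=C1/C(=C/c2ccncc2)CN(S(=O)(=O)c2ccc(F)cc2)C/C1=C\c1ccccc1C(F)(F)F`: 9270 nM

All three were measured in a functional assay on SMMC-7721 cells (Homo sapiens) for cytotoxicity, read by MTT assay, with a stated time of 24 h; on this read-out lower numbers stand for stronger inhibition and higher numbers for weaker inhibition. Compound 2 reads > 20000 nM, which is a limit and not a number (the limit of > 20000 nM in this assay, at which 1 of the 3 values shown sits). Compound 3 gives 9270 nM and sits within the scatter of compound 1 at 9600 nM, so these two numbers cannot be ordered.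

The next compound is compound 4 `O=C1/C(=C/c2ccncc2)CN(S(=O)(=O)c2ccc(Cl)cc2)C/C1=C\c1ccccc1C(F)(F)F`, which differs from compound 3 by one exchange, chloro in place of fluoro on an aromatic carbon, para to a large group.

Among the measured compounds shown here, one measured step bears directly on this place, and it is a different exchange: fluoro in place of nitro gave an at least 2.1-fold lower number from compound 2 to compound 3 (0.33 log units; beyond the scatter). It shows that this assay can respond to a change at this place, but it does not measure chloro against fluoro. Compound 1 also carries a 4-chlorophenyl and gives 9600 nM, though it is not a matched comparison for compound 4.

No step beyond the scatter is therefore expected in this assay, and no direction is favoured. The expected result is a 1.0-fold lower number from compound 3 to compound 4 (0.01 log units; within the scatter). For compound 4 the estimated value is 9000 nM, with an expected range of 4500 nM to 18000 nM.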

Compound 4, half-maximal inhibitory concentration: 5510 nM
Estimate against measurement, compound 4: 1.6-fold (0.21 log units) above, and the stated range covers the measured number.
By their numbers in this assay, from the lowest: compounds 4, 3 and 1 (each within the scatter of the next). At a limit, above all of these: compound 2.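

In this assay, among the compounds shown here, the exchange of 4-fluorophenyl for 4-chlorophenyl on the sulfonyl gives a 1.7-fold lower number from compound 3 to compound 4 (0.23 log units; within the scatter), the first direct reading of chloro against fluoro at this place, and it does not separate the two halogens; the change from fluoro to trifluoromethyl elsewhere on the core gives a 1.7-fold lower number from compound 1 to compound 4 (0.24 log units; within the scatter) and does not separate those two groups either. Chloro in place of nitro gives an at least 3.6-fold lower number from compound 2 to compound 4 (0.55 log units; beyond the scatter), so chloro as well as fluoro now reads beyond the scatter from nitro at this place, and the earlier fluoro step, an at least 2.1-fold lower number from compound 2 to compound 3 (0.33 log units; beyond the scatter), no longer stands alone. Compound 2 gives only a limit, so the full size of both steps from it stays unknown: the limit of > 20000 nM in this assay, at which 1 of the 4 values shown sits.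

The compounds shown leave open whether a bromo, methyl, methoxy or dimethylamino group at this place would read with the two halogens or with nitro. They also leave open whether an unsubstituted phenyl on the sulfonyl, or a carboxylic acid or primary amine at this place, would move the number beyond the scatter of the halogens.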